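This account rests on a few compounds, and the source may have more. Where it says the series, first, only, none or still open, it means among the compounds named here.

Compound 1 `CC(C)c1cc(C(=O)Nc2ccc(NC(=O)CCCCCCC(=O)NO)cc2)c(O)cc1O` gives in a functional assay on A549 cells (Homo sapiens) for inhibition, read by sulforhodamine B assay, with a stated time of 48 h (a higher number here means a weaker inhibitor of growth, a lower number a stronger inhibitor of growth), only a limit, > 10000 nM, not a number. Compound 1 therefore stands at the limit of > 10000 nM in this assay, at which 1 of the 2 values shown sits, with no measured value of its own. Compound 2 `CCN(C(=O)c1cc(C(C)C)c(O)cc1O)c1cccc(NC(=O)CCCCCCC(=O)NO)c1` gives in this assay 1590 nM. Compound 3 `CC(C)c1cc(C(=O)N(c2ccc(NC(=O)CCCCCCC(=O)NO)cc2)C(C)C)c(O)cc1O` differs from compound 1 by isopropyl in place of hydrogen on an amide-type nitrogen. Within the data shown here, no measured pair isolates this change; compound 2 also carries an alkyl group on its amide nitrogen, but it differs from compound 1 in more than one place, so it shows only that such a substituted amide can reach the value of compound 2, 1590 nM. For compound 3 a gain beyond the scatter is expected, a step of an at least 3.3-fold lower number from compound 1 to compound 3 (0.52 log units; beyond the scatter). Compound 3 is estimated at 3000 nM, within 800 nM to 15000 nM.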

Compound 3, concentration for 50% growth inhibition: > 10000 nM
Compound 3: a limit, no number; the forecaster's own chance of this, stated with the estimate: 35%; middle value at least 3.3-fold (0.52 log units) from the limit.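

In this assay compound 3 gives > 10000 nM, a limit and not a number. Among these compounds, compound 1 also stands at a limit, so no step between compound 1 and compound 3 can be read. Still open, from the compounds shown here alone, is whether isopropyl in place of hydrogen on an amide-type nitrogen changes growth inhibition at all.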